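The source may report more compounds than this note shows. Statements on the series, on what has been measured and on what is new or still open speak of the compounds shown alone.

Measured so far:
compound 1 `O=[N+]([O-])c1ccc(C(F)F)cc1`: 2.12
compound 2 `N#Cc1ccc(C(F)F)cc1`: 1.75

Of the compounds shown here, two sharing one core have been measured in a physicochemical assay for lipophilicity, read by spectrophotometry, using the shake flask method, measured as octanol-water partition; a higher number here means a more lipophilic compound, a lower number a more polar compound. Compound 1 `O=[N+]([O-])c1ccc(C(F)F)cc1` gives 2.12 in this assay, and compound 2 `N#Cc1ccc(C(F)F)cc1` gives 1.75. Going by the values given here, the one step between them, cyano in place of nitro on an aromatic carbon, is a number 0.37 log units lower from compound 1 to compound 2 (beyond the scatter), so compound 2 stands as the lower of the two numbers, with compound 1 the nearest neighbour.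

Compound 3 `COc1ccc(C(F)F)cc1` differs from compound 2 as follows: methoxy in place of cyano on an aromatic carbon. Among the compounds with values here, no measured step covers this swap; the only step seen, from compound 1 to compound 2, exchanges a different pair of groups, so it offers no direct guide to the size or direction here. With both measured values lying close together, the expectation for compound 3 is a value near them, with an estimated step of a number 0.55 log units higher from compound 2 to compound 3 (beyond the scatter) in this assay. Compound 3 is therefore expected to give about 2.3, in a range from 1.9 to 2.7.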

Compound 3, partition coefficient: 2.61
Compound 3: the middle estimate sits 0.31 log units below what was measured, within the range that was stated.
By their numbers in this assay, from the lowest: compound 2; then compound 1; then compound 3.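

At this position, para to a difluoromethyl group, the three groups now give clearly different numbers in this assay: methoxy in place of cyano gives the larger step (a number 0.86 log units higher from compound 2 to compound 3 (beyond the scatter)), and methoxy in place of nitro gives a smaller one (a number 0.49 log units higher from compound 1 to compound 3 (beyond the scatter)). Compound 3 therefore stands highest of the three, with both of its steps beyond the scatter. Cyano and methoxy each have 2 heavy atoms and 1 hydrogen-bond acceptor, so those counts do not separate them, and nothing available here explains the difference.

Where an amine, a carboxylic acid or a longer ether chain would fall at this position remains open. So does whether these steps would keep their size and direction on a different core.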